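The source may report more compounds than this note shows. Statements on the series, on what has been measured and on what is new or still open speak of the compounds shown alone.

Compound 1 `c1ccc(Oc2ccc3c(NCCCNCc4ccco4)ccnc3c2)cc1` gives 9.28 in a physicochemical assay for acid dissociation.
Compound 2 `COc1cccc(Oc2ccc3c(NCCCNCc4cc(F)ccc4OC)ccnc3c2)c1` gives 9.28 in this assay.
Compound 3 `COc1ccc(F)cc1CNCCCNc1ccnc2cc(Cc3cccc(C(F)(F)F)c3)ccc12` gives 9.47 in this assay.

Of the three measured compounds, compound 3 carries the number that sits at the upper end, yet the numbers of compound 1 and compound 2 both lie within the scatter of it, so the three cannot be told apart on these data. Among the compounds with values here, the one measured step that changes a single place, a number 0.19 log units higher from compound 2 to compound 3 (within the scatter), is itself within the scatter.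

Compound 4 `COc1ccc(F)cc1CNCCCNc1ccnc2cc(Oc3ccccc3)ccc12` has not yet been measured. It differs from compound 3 in one place: phenoxy in place of 3-(trifluoromethyl)benzyl on an aromatic carbon. Within the data shown here, the only step that bears on this is the one that went the other way on the same aromatic carbon, from 3-methoxyphenoxy to 3-(trifluoromethyl)benzyl, and it moved the number by no more than the scatter. Going back from the 3-(trifluoromethyl)benzyl to a phenoxy is therefore expected to leave this assay essentially where it is, with the step of a number 0.17 log units lower from compound 3 to compound 4 (within the scatter) expected to fall inside the scatter. Compound 4 is accordingly estimated at 9.3, with a range from 9.05 to 9.55.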

Compound 4, acid dissociation constant: 9.28
The estimate for compound 4 lay 0.02 log units above the measured number, and the stated range covers the measured number.
By their numbers in this assay, from the lowest: compounds 1, 2, 4 and 3 (each within the scatter of the next).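

In this assay, the aromatic carbon that is meta to a fused ring and para to a fused ring now has three groups that can be compared, and phenoxy in place of 3-(trifluoromethyl)benzyl gives a number 0.19 log units lower from compound 3 to compound 4 (within the scatter) while hydrogen in place of methoxy on the phenoxy group gives no change at the digits printed from compound 2 to compound 4 (within the scatter), so no group read so far on this carbon stands apart from the others. Compound 4 also opens a comparison in a second place, the saturated chain carbon bound to an amine nitrogen, where 5-fluoro-2-methoxyphenyl in place of furan-2-yl gives no change at the digits printed from compound 1 to compound 4 (within the scatter), and so neither of the two places has yet moved the number beyond the scatter. Nothing among the data shown speaks to what lies behind these closely grouped numbers.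

On these data alone, whether a primary amine or a carboxylic acid on this aromatic carbon, or a longer chain linking the two amine nitrogens, would carry the number beyond the scatter stays open. The compounds shown also leave open which proton in these molecules the number belongs to.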